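The source may hold more compounds than are shown below. What is called first, only, known or untested is meant among the compounds shown, and "the series" means these compounds.

Notes on the series. Compound 2 `COC(=O)c1ccc(OCCCCOc2ccc(C(=O)CC3CCCC3)c(C)c2C)cc1` gives the highest of the three numbers in an assay on HEK293 cells for positive allosteric modulation of metabotropic glutamate receptor 3 (Rattus norvegicus), read by thallium flux, with a stated time of 2.5 min (a lower number here means a smaller maximal response, a higher number a larger maximal response), at 24.2%. Compound 1 `COC(=O)c1ccc(OCCCCOc2ccc(C(=O)CC3CCCC3)c(O)c2C)cc1` gives 22% in this assay, so that a number 2.2 percentage points higher from compound 1 to compound 2 (within the scatter). Compound 3 `Cc1c(OCCCCOc2ccc(C(=O)O)c(Cl)c2)ccc(C(=O)CC(C)C)c1C`, which carries a carboxylic acid, gives 12% in this assay, the lowest of the three and beyond the scatter from compound 2. Compound 4 `Cc1c(OCCCCOc2cccc(C(=O)O)c2)ccc(C(=O)CC2CCCC2)c1C` has not yet been measured in this assay; it differs from compound 2 by 3-carboxyphenyl in place of 4-(methoxycarbonyl)phenyl on an oxygen on a saturated carbon. Among the measured compounds shown here, no single-place step with this change has been measured; the only bearing numbers are those of compound 3 and compound 2, which point to a lower value for an acid. The estimate for compound 4 in this assay is 15%, within 5% to 27%, an expected downward step of a number 9.2 percentage points lower from compound 2 to compound 4 (within the scatter).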

Compound 4, largest response reached (reported as percent of maximum), in percent of the reference or control that the assay uses: 16.5%
Compound 4: the middle estimate sits 1.5 percentage points below what was measured; the measured number falls inside the stated range.
By their numbers in this assay, from the lowest: compounds 3, 4, 1 and 2 (each within the scatter of the next, the first and the last beyond it).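

Among the compounds shown here, at the position on an oxygen on a saturated carbon, 3-carboxyphenyl in place of 4-(methoxycarbonyl)phenyl gives, in this assay, a number 7.7 percentage points lower from compound 2 to compound 4 (within the scatter) and so is the first single-place reading of this exchange. On the shared core, the two groups are not separated in this assay. No measured evidence bears on this result.

As far as these compounds go, the step changes the group and its numbered ring place together, so which of the two matters stays open. Also open, from the compounds shown here alone, is how a carboxamide or a longer chain would read at this place.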